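The source may report more compounds than this note shows. Statements on the series, on what has been measured and on what is new or still open speak of the compounds shown alone.

Measured so far:
Compound 1 (`O=C1NCCC12CCN(c1c(Cl)cncc1-c1cccs1)CC2`): 480 nM
Compound 2 (`CCOCOCc1ccc(-c2cncc(Cl)c2N2CCC3(CCNC3=O)CC2)o1`): 2970 nM

In a functional assay on MV4-11 cells (Homo sapiens) for inhibition, read by resazurin assay, with a stated time of 72 h (on this read-out lower numbers stand for stronger inhibition of growth and higher numbers for weaker inhibition of growth), compound 1 gives 480 nM and stands lowest of the two numbers, while compound 2 gives 2970 nM on the weaker side, a gap beyond the usual scatter. Compound 3 (`Cc1ccsc1-c1cncc(Cl)c1N1CCC2(CCNC2=O)CC1`) has not yet been measured. It departs from compound 1 at one place, thiophen-2-yl to 3-methylthiophen-2-yl, with methyl in place of hydrogen on an aromatic carbon. For the measured compounds named here, no measured pair shows this change, so the expectation is loose: a small step in this assay toward a higher number, possibly none beyond the scatter. The expected step of a 1.5-fold higher number from compound 1 to compound 3 (0.16 log units; within the scatter) is an estimate only. Compound 3 is estimated at 700 nM as a middle value, with an expected range from 250 nM to 2000 nM in this assay for now.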

Compound 3, concentration for 50% growth inhibition: 910 nM
The estimate for compound 3 lay 1.3-fold (0.11 log units) below the measured number; the range from low to high includes it.
By their numbers in this assay, from the lowest: compounds 1 and 3 (each within the scatter of the next); then compound 2.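

In this assay, for the compounds shown here, the pair of compound 1 and compound 3 is the first to differ in one place only, and it gives a 1.9-fold higher number from compound 1 to compound 3 (0.28 log units; within the scatter) for the change from thiophen-2-yl to 3-methylthiophen-2-yl. The two numbers cannot be told apart, so this aromatic carbon, next to the ring atom that bears a large group, accepts a methyl without a step beyond the scatter on this read-out. Nothing shown explains this result or gives a measured property of the methyl at this place.

This is a single pair, so it sets no pattern for the position. On these data alone, whether an ethyl, a methoxy or an amine on the same carbon would also stay within the scatter of compound 1 remains open, as does the effect of a methyl on the other carbons of the ring.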